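A few compounds are considered here, and "the series" means these few. Any claim that something is new, unique, unknown or untested is made for them only; others in the source may bear on it.

Measured so far in an assay on isolated protein for antagonist activity at Voltage-dependent L-type calcium channel subunit alpha-1C (Cavia porcellus), with a stated time of 15 min; a higher number here means a weaker inhibitor, a lower number a stronger inhibitor:
Compound 1 `CC1=C(C(=O)OCCc2ccccc2)C(c2csc(-c3ccc(Cl)cc3)n2)C(C(=O)OCCc2ccccc2)=C(C)N1` gives 500000 nM.
Compound 2 `CCOC(=O)C1=C(C)NC(C)=C(C(=O)OC2CCCCC2)C1c1csc(-c2ccc(Cl)cc2)n1` gives 100000 nM.

Compound 2 holds the lower of the two numbers in this assay; compound 1 sits higher, and that gap lies beyond the usual scatter. Going by the values given here, no pair of measured compounds differs in a single place, so no single step is known from the data.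

Compound 3 `CCOC(=O)C1=C(C)NC(C)=C(C(=O)OCCc2ccccc2)C1c1csc(-c2ccc(Cl)cc2)n1` has not yet been measured. It derives from compound 2 by the change (phenethyl in place of cyclohexyl on an oxygen next to a carbonyl group). A phenethyl ester appears at both ester positions of compound 1, the compound with the higher number of the two, but compound 1 also differs from compound 3 at the other ester, so that comparison is not clean. The expected step is a 2.0-fold higher number from compound 2 to compound 3 (0.30 log units; within the scatter), a modest move toward a higher number, if any beyond the scatter. For compound 3 the estimated value in this assay is 200000 nM, with a range from 70000 nM to 600000 nM.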

Compound 3, half-maximal inhibitory concentration: 12100 nM
Compound 3: middle estimate off by 17-fold (1.22 log units), on the high side; the measured number lies below the stated range.
By their numbers in this assay, from the lowest: compound 3; then compound 2; then compound 1.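

In this assay the ester position responds strongly to the group it carries: phenethyl in place of cyclohexyl on an oxygen next to a carbonyl group gives an 8.3-fold lower number from compound 2 to compound 3 (0.92 log units; beyond the scatter) and makes compound 3 the lowest of the three. Phenethyl does not lower the number at every ester, since hydrogen in place of phenyl on a saturated chain carbon at the other ester gives a 41-fold lower number from compound 1 to compound 3 (1.62 log units; beyond the scatter) and so the second phenyl ring in compound 1 goes with a much weaker inhibitor. No available data explain either step.

On these data alone, it remains open whether the lower number of compound 3 depends on the aromatic ring or on the chain that carries it. A cyclohexylethyl ester, a longer chain ending in phenyl, or a terminal amine would separate these possibilities.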